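Notes on a formyl to carboxyethenyl exchange

The compounds below may be only part of what the source reports. "The series", "measured", "known", "first", "only" and "open" are said of these compounds alone.

Measured values in a functional assay (Mus musculus) for inhibition, with a stated time of 5 days; on this read-out higher numbers stand for weaker inhibition and lower numbers for stronger inhibition:
compound 1 `O=C(O)/C=C/c1cn(-c2ccc(O)cc2)nc1-c1cccc(O)c1`: a limit only, > 100000 nM
compound 2 `O=Cc1cn(-c2ccc(O)cc2)nc1-c1cccc(O)c1`: 42000 nM
compound 3 `O=Cc1cn(-c2ccc(O)cc2)nc1-c1ccc(O)c(O)c1`: 12000 nM

Two steps are measured. The change from compound 2 to compound 3 is hydroxy in place of hydrogen on an aromatic carbon; the step is a 3.5-fold lower number from compound 2 to compound 3 (0.54 log units; beyond the scatter), and compound 3 holds the lower of the two measured numbers. The change from compound 2 to compound 1 is 2-carboxyethenyl in place of formyl on an aromatic carbon; the step is an at least 2.3-fold higher number from compound 2 to compound 1 (0.37 log units; beyond the scatter), its size bounded only by the limit of > 100000 nM in this assay, at which 1 of the 3 values shown sits.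

Compound 4 `O=C(O)/C=C/c1cn(-c2ccc(O)cc2)nc1-c1ccc(O)c(O)c1` is not yet measured in this assay; it differs from compound 3 by 2-carboxyethenyl in place of formyl on an aromatic carbon. The surroundings of the exchange differ in one respect: for compound 1 the carbon sits next to the ring atom that bears a 3-hydroxyphenyl group (7 heavy atoms), for compound 4 next to the ring atom that bears a group of 8 heavy atoms, so the two changes are of the same kind rather than the same.

With a single, open-ended example of this exchange, the expectation rests on an at least 2.3-fold higher number from compound 2 to compound 1 (0.37 log units; beyond the scatter) alone: compound 4 is expected to show a step of a 3.3-fold higher number from compound 3 to compound 4 (0.52 log units; beyond the scatter). The estimate for compound 4 is 40000 nM, roughly 15000 nM to 150000 nM, with a real chance that only a limit is reported.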

Compound 4, half-maximal inhibitory concentration: > 100000 nM
Compound 4 gave a limit, no number (the forecaster's own chance of this, stated with the estimate: 30%); middle value at least 2.5-fold (0.39 log units) away from the limit.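

In this assay compound 4 gives > 100000 nM, which is a limit and not a number. Replacing formyl with 2-carboxyethenyl gives an at least 8.3-fold higher number from compound 3 to compound 4 (0.92 log units; beyond the scatter), so inhibition weakens on the core of compound 3 as it does on the core of compound 2, and the direction of the change carries over in both examples: the same change on two cores in this assay, an at least 2.3-fold higher number (0.37 log units; beyond the scatter) from compound 2 to compound 1 and an at least 8.3-fold higher number (0.92 log units; beyond the scatter) from compound 3 to compound 4; the limit leaves it open whether they differ

The step from compound 1 to compound 4 cannot be read, and neither exchange has a full size, so the series supports a shared direction but no transferable magnitude: the limit of > 100000 nM in this assay, at which 2 of the 4 values shown sit.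

On these data alone, it remains open whether the weaker inhibition goes with the carboxylic acid or with the longer chain, a question that a methyl ester or a primary amide on the same ethenyl chain could separate. Also open, as far as these compounds go, is whether the added hydroxy of compound 4 keeps, on the 2-carboxyethenyl core, the gain seen on the formyl core.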